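The compounds below may be only part of what the source reports. "The series", "measured", "known", "first", "only" and "open" are said of these compounds alone.

Of the compounds shown here, two with a shared core have been measured in a functional assay on the whole organism for inhibition, with Mus musculus as the target, at a dose of 25 mg/kg by the oral route; a higher number here means more inhibition at the dose given (going by the name of the read-out), a lower number less inhibition. Compound 1, `Clc1cc(Cl)cc(N2CCN(CCCOc3ccc4c(c3)CCC4)CC2)c1`, carries a 3,5-dichlorophenyl on an amine nitrogen in a ring, and in this assay compound 1 gives 0%. Compound 2, `COc1ccc(N2CCN(CCCOc3ccc4c(c3)CCC4)CC2)cc1`, carries a 4-methoxyphenyl at that position instead, and in this assay compound 2 gives 37%. That single step, 4-methoxyphenyl in place of 3,5-dichlorophenyl on an amine nitrogen in a ring, is recorded as a number 37 percentage points higher from compound 1 to compound 2 (beyond the scatter). Compound 2 therefore stands highest of the two numbers, with compound 1 as the nearest neighbour at a value beyond the scatter below it.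

Compound 3, `CC(=O)c1ccc(N2CCN(CCCOc3ccc4c(c3)CCC4)CC2)cc1`, has not yet been measured. It differs from compound 2 as follows: acetyl in place of methoxy on an aromatic carbon. For the measured compounds named here, the only measured step, from compound 1 to compound 2, changed the same aryl group on the same ring nitrogen and was large, so the read-out is clearly sensitive to what stands there, but no measured step exchanges a substituent in this position of the phenyl ring. The direction of the step from compound 2 to compound 3 in this assay is therefore uncertain, and it is expected to be modest, a number 7 percentage points lower from compound 2 to compound 3 (within the scatter). Compound 3 is estimated to give 30% in this assay, within a range from 5% to 60%.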

Compound 3, a percentage reported as inhibition, in the whole organism at one dose (the size of the read-out at that dose, not a potency): 0%
Compound 3: middle estimate off by 30 percentage points, on the high side; measured number outside the range, below it.
By their numbers in this assay, from the lowest: compounds 1 and 3 (each within the scatter of the next); then compound 2.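

The exchange of methoxy for acetyl on an aromatic carbon, para to a large group, is recorded as a number 37 percentage points lower from compound 2 to compound 3 (beyond the scatter) in this assay, so this read-out responds to a single substituent at this place on the phenyl ring, and not only to the replacement of the whole aryl group. The exchange leaves the counts of hydrogen-bond donors and acceptors unchanged, so those counts alone do not separate the two compounds, and the 4-acetylphenyl group gives no separation from the 3,5-dichlorophenyl group either, with no change at the digits printed from compound 1 to compound 3 (within the scatter), leaving compound 2 as the only one of the three set apart by steps beyond the scatter. Nothing measured here bears on why the acetyl group behaves differently from the methoxy group.

From the compounds shown here alone, whether the result is particular to methoxy or extends to an ethoxy, a hydroxyl or an amino group on the same carbon remains open. Also open, going by these compounds, is whether compound 1 and compound 3 would separate at another dose, since this read-out gives the size of the effect at one dose and is not a potency.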